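This account rests on a few compounds, and the source may have more. Where it says the series, first, only, none or still open, it means among the compounds named here.

Measured compounds:
- compound 1 `CNc1nc(-c2cc(OC)c(OC)c(OC)c2)c(-c2ccc(C(F)(F)F)cc2)s1`: 4570 nM
- compound 2 `CNc1nc(-c2cc(OC)c(OC)c(OC)c2)c(-c2ccc(OC)cc2)s1`: 138 nM
- compound 3 `COc1cc(-c2nc(C)sc2-c2ccc(C(F)(F)F)cc2)cc(OC)c1OC`: 4290 nM

All three were read in a functional assay on A549 cells (Homo sapiens) for antiproliferative activity, read by MTT assay, with a stated time of 72 h; on this read-out lower numbers stand for stronger inhibition and higher numbers for weaker inhibition. Two single changes connect them. Compound 1 to compound 2 is methoxy in place of trifluoromethyl on an aromatic carbon and gives a 33-fold lower number from compound 1 to compound 2 (1.52 log units; beyond the scatter). Compound 1 to compound 3 is the core change methyl in place of methylamino on an aromatic carbon and gives a 1.1-fold lower number from compound 1 to compound 3 (0.03 log units; within the scatter), so the two cores, methylamino-bearing and methyl-bearing, stand close in this assay.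

Compound 4 `COc1ccc(-c2sc(C)nc2-c2cc(OC)c(OC)c(OC)c2)cc1` has not been measured. It differs from compound 3 by methoxy in place of trifluoromethyl on an aromatic carbon. This is the same change as from compound 1 to compound 2: the leaving group, the entering group and the place are described in the same words, so the pair compound 3 to compound 4 repeats that pair on the other core.

Since the core difference itself left the number nearly unchanged in compound 1 to compound 3 a 1.1-fold lower number from compound 1 to compound 3 (0.03 log units; within the scatter), the step for compound 4 is expected to resemble a 33-fold lower number from compound 1 to compound 2 (1.52 log units; beyond the scatter), estimated as a 31-fold lower number from compound 3 to compound 4 (1.49 log units; beyond the scatter). Compound 4 is therefore estimated at 140 nM in this assay, expected between 50 nM and 400 nM.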

Compound 4, half-maximal inhibitory concentration: 2560 nM
Beside the measured number, compound 4's estimate is 18-fold (1.26 log units) below it; measured number above the stated range.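

In this assay, methoxy in place of trifluoromethyl gives a 1.7-fold lower number from compound 3 to compound 4 (0.22 log units; within the scatter) on the methyl-bearing core, so the large step seen on the methylamino-bearing core does not carry over to this core: the same change on two cores in this assay, a 33-fold lower number (1.52 log units; beyond the scatter) from compound 1 to compound 2 and a 1.7-fold lower number (0.22 log units; within the scatter) from compound 3 to compound 4, 20-fold (1.30 log units) apart, beyond the scatter of two such steps

Read along the other edge, methyl in place of methylamino gives a 19-fold higher number from compound 2 to compound 4 (1.27 log units; beyond the scatter) when methoxy is present, so the effect of the core change also depends on the group on the aromatic carbon: the same change on two cores in this assay, a 1.1-fold lower number (0.03 log units; within the scatter) from compound 1 to compound 3 and a 19-fold higher number (1.27 log units; beyond the scatter) from compound 2 to compound 4, 20-fold (1.30 log units) apart, beyond the scatter of two such steps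

The four compounds show that the two changes do not add up independently, with the low number appearing only when methylamino and methoxy occur together in compound 2, but they do not show why this is so or whether it extends beyond this pair of groups.

The compounds shown leave open whether an amino or dimethylamino group in place of methylamino would keep the low number of compound 2. Also open, on these data alone, is whether ethoxy or chlorine in place of methoxy would behave the same way on either core.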